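Swapping the aryl amide of compound 1 for a dichlorophenyl

The compounds below may be only part of what the source reports. "The series", "measured", "known", "first", "only" and "open" are said of these compounds alone.

Compound 1 `CN(C(=O)NC(=O)c1cccc([N+](=O)[O-])c1)c1nc(C(F)(F)F)c(C(=O)N/N=C/c2ccccc2C(F)(F)F)s1` is examined in a functional assay on A549 cells (Homo sapiens) for inhibition, read by MTT assay, with a stated time of 72 h (on this read-out lower numbers stand for stronger inhibition and higher numbers for weaker inhibition), where compound 1 gives 5.45 ug/mL. Among the three measured compounds this is the lowest number. Compound 3 `CN(C(=O)NC(=O)c1cccc(C(F)(F)F)c1)c1nc(C(F)(F)F)c(C(=O)N/N=C/c2ccc(C(F)(F)F)cc2)s1` sits within the scatter of it, with compound 3 giving 6.2 ug/mL. Compound 2 `Cc1nc(N(C)C(=O)NC(=O)c2ccc(Cl)cc2Cl)sc1C(=O)N/N=C/c1ccc(C(F)(F)F)cc1` lies beyond the scatter above it, with compound 2 giving 30.2 ug/mL; compound 2 differs from compound 1 in several places, so its value alone tells what the dichlorophenyl group does.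

Compound 4 `CN(C(=O)NC(=O)c1ccc(Cl)cc1Cl)c1nc(C(F)(F)F)c(C(=O)N/N=C/c2ccccc2C(F)(F)F)s1` is not yet measured. The change is 2,4-dichlorophenyl in place of 3-nitrophenyl on a carbonyl carbon. Compound 2 also carries the 2,4-dichlorophenyl and shows the weakest number, so a modest rise is expected. In this assay compound 4 is expected to give 10 ug/mL, in the range 4 ug/mL to 25 ug/mL, a step of a 1.8-fold higher number from compound 1 to compound 4 (0.26 log units; within the scatter).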

Compound 4, half-maximal inhibitory concentration: 15.3 ug/mL
The estimate for compound 4 lay 1.5-fold (0.18 log units) below the measured number; the range from low to high includes it.
By their numbers in this assay, from the lowest: compounds 1 and 3 (each within the scatter of the next); then compounds 4 and 2 (each within the scatter of the next).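

Going by these compounds alone, with only this change on a carbonyl carbon and the rest of the molecule held constant, 2,4-dichlorophenyl in place of 3-nitrophenyl gives a 2.8-fold higher number from compound 1 to compound 4 (0.45 log units; beyond the scatter) in this assay. Within the data shown here, the earlier compounds differed in several places, so this is the first reading showing that the aryl group here affects the number on its own. Nothing available explains the step. Still open, on these data alone, is whether a single chlorine or the nitro group matters more. As far as these compounds go, how a plain phenyl, a 4-methoxyphenyl or a pyridine ring would read at this place also remains unknown.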